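The source may hold more compounds than are shown below. What is called first, only, known or untested is meant among the compounds shown, and "the series" means these compounds.

Compound 3 `COc1cccc(CNCCCNc2ccnc3cc(Oc4ccccc4)ccc23)c1O` stands second highest of the three compounds measured in a physicochemical assay for solubility, with a stated time of 18 h, at pH 7.4 (on this read-out lower numbers stand for lower solubility and higher numbers for higher solubility), where compound 3 gives 14500 nM. Its nearest neighbour, compound 2 `COc1cccc(CNCCCNc2ccnc3cc(-c4ccccc4)ccc23)c1O`, gives 32000 nM; the step is a 2.2-fold lower number from compound 2 to compound 3 (0.34 log units; beyond the scatter). Furthest away, compound 1 `CCC(CC)c1ccc2c(NCCCNCc3cccc(OC)c3O)ccnc2c1` gives 4200 nM; the step is a 3.5-fold higher number from compound 1 to compound 3 (0.54 log units; beyond the scatter), and a 7.6-fold higher number from compound 1 to compound 2 (0.88 log units; beyond the scatter). Compound 4 `COc1cccc(CNCCCNc2ccnc3cc(CC4CCCCC4)ccc23)c1O` differs from compound 3 in one place: cyclohexylmethyl in place of phenoxy on an aromatic carbon. The steps from compound 1 bear most on this change, as cyclohexylmethyl, like pentan-3-yl, has no aromatic ring and no hydrogen-bond acceptor, and both steps were modest. A modest fall is therefore expected for compound 4 in this assay, estimated at 4500 nM with a range from 1800 nM to 12000 nM. The expected step is a 3.2-fold lower number from compound 3 to compound 4 (0.51 log units; beyond the scatter).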

Compound 4, solubility: 4200 nM
Beside the measured number, compound 4's estimate is 1.1-fold (0.03 log units) above it, within the range that was stated.
By their numbers in this assay, from the lowest: compounds 1 and 4 (each within the scatter of the next); then compound 3; then compound 2.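

Among these four compounds, the two groups carrying an aromatic ring, phenoxy and phenyl, give higher numbers in this assay than cyclohexylmethyl does (a 3.5-fold lower number from compound 3 to compound 4 (0.54 log units; beyond the scatter); a 7.6-fold lower number from compound 2 to compound 4 (0.88 log units; beyond the scatter)). Cyclohexylmethyl and pentan-3-yl, neither of which has an aromatic ring, cannot be told apart (no change at the digits printed from compound 1 to compound 4 (within the scatter)), so at this position a six-membered non-aromatic ring reads the same as the open pentan-3-yl. Nothing measured here gives a reason for these steps.

Going by these compounds, whether an amine or a carboxylic acid at this position would shift the number stays open, as does whether a pyridine ring would read like phenyl.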